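Paw edema series: removing the sulfamoylthiophene arm

A few compounds are considered here, and "the series" means these few. Any claim that something is new, unique, unknown or untested is made for them only; others in the source may bear on it.

Measured so far:
compound 1 `Cc1ccc(OCc2ccccc2-c2nc(-c3cc(Cl)sc3S(N)(=O)=O)cs2)cc1` 68.7%
compound 2 `NS(=O)(=O)c1sc(Cl)cc1-c1csc(-c2ccccc2COc2ccc(Cl)cc2)n1` 76.4%

Among the measured compounds shown here, in a functional assay on the whole organism (strain Wistar albino) for inhibition, with Rattus norvegicus as the target, read by paw edema, at a dose of 10 mg/kg by the oral route (a higher number here means more inhibition at the dose given (going by the name of the read-out), a lower number less inhibition), compound 2 gives 76.4%, the higher of the two numbers; the only step, a number 7.7 percentage points higher from compound 1 to compound 2 (within the scatter), lies within the scatter. Compound 3 `Clc1ccc(OCc2csc(-c3ccccc3COc3ccc(Cl)cc3)n2)cc1` is not yet measured in this assay; the change is (4-chlorophenoxy)methyl in place of 5-chloro-2-sulfamoylthiophen-3-yl on an aromatic carbon. For the measured compounds named here, no measured step touches this position, so the size and direction are uncertain; a moderate fall from compound 2 is expected. Compound 3 is estimated at 55%, range 35% to 75%, a step of a number 21.4 percentage points lower from compound 2 to compound 3 (beyond the scatter).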

Compound 3, a percentage reported as inhibition, in the whole organism at one dose (the size of the read-out at that dose, not a potency): 76.4%
Estimate against measurement, compound 3: 21.4 percentage points below; the measured number lies above the stated range.
By their numbers in this assay, from the lowest: compounds 1, 2 and 3 (each within the scatter of the next).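

Replacing 5-chloro-2-sulfamoylthiophen-3-yl with (4-chlorophenoxy)methyl on this aromatic carbon gives no change at the digits printed from compound 2 to compound 3 (within the scatter) in this assay. At this dose, the sulfamoylthiophene arm is therefore not required at this position, and a group with one six-membered aromatic ring of carbon only and no hydrogen-bond donors can take its place. Nothing available explains this equivalence. Going by these compounds, whether a carboxylic acid or an aminomethyl group on this carbon would retain the inhibition remains open. On these data alone, the comparison also rests on a single oral dose, so behaviour at other doses remains open.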